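The source may report more compounds than this note shows. Statements on the series, on what has been measured and on what is new or still open speak of the compounds shown alone.

Three compounds sharing one core differ only in the aryl group on an aromatic nitrogen. In a functional assay on A549 cells (Homo sapiens) for inhibition, read by MTT assay, with a stated time of 24 h (a higher number here means a weaker inhibitor, a lower number a stronger inhibitor), compound 1 `Cc1ccccc1-n1cc(CN2C(=O)C[C@@H]3CC[C@@]2(C)C3(C)C)nn1` gives 90 nM, compound 2 `CC1(C)[C@H]2CC[C@]1(C)N(Cc1cn(-c3cccc(O)c3)nn1)C(=O)C2` gives 180 nM and compound 3 `CC1(C)[C@H]2CC[C@]1(C)N(Cc1cn(-c3ccc(Br)cc3)nn1)C(=O)C2` gives 80 nM, the lowest number of the three, though a 1.1-fold lower number from compound 1 to compound 3 (0.05 log units; within the scatter) while a 2.3-fold lower number from compound 2 to compound 3 (0.35 log units; beyond the scatter). Compound 4 `CC1(C)[C@H]2CC[C@]1(C)N(Cc1cn(-c3cccc(C#N)c3)nn1)C(=O)C2` is not yet measured; it differs from compound 3 in one place: 3-cyanophenyl in place of 4-bromophenyl on an aromatic nitrogen. Both measured aryl exchanges on this nitrogen bear on the step: one stayed within the scatter, the other was modest. A step of similar size, if any, is expected in this assay, most likely toward a higher number, as seen for compound 2 at 180 nM. Compound 4 is therefore estimated at 120 nM, range 60 nM to 250 nM, which means a 1.5-fold higher number from compound 3 to compound 4 (0.18 log units; within the scatter).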

Compound 4, half-maximal inhibitory concentration: 440 nM
For compound 4 the middle estimate is 3.7-fold (0.56 log units) below the measured one; measured number above the stated range.
By their numbers in this assay, from the lowest: compounds 3, 1 and 2 (each within the scatter of the next, the first and the last beyond it); then compound 4.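

Going by these compounds alone, with 3-cyanophenyl on the aromatic nitrogen, compound 4 is the weakest of the four, with a 5.5-fold higher number from compound 3 to compound 4 (0.74 log units; beyond the scatter) and a 4.9-fold higher number from compound 1 to compound 4 (0.69 log units; beyond the scatter); these steps exceed any seen among the earlier compounds. Cyano in place of hydroxy on an aromatic carbon alone gives a 2.4-fold higher number from compound 2 to compound 4 (0.39 log units; beyond the scatter), so this exchange on the phenyl ring is not neutral. No available evidence accounts for these steps. Open, from the compounds shown here alone, is whether 3-bromophenyl or 3-aminophenyl would stand nearer compound 3 or compound 4, which would separate the effect of the group from that of its place.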